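A few compounds are considered here, and "the series" means these few. Any claim that something is new, unique, unknown or untested is made for them only; others in the source may bear on it.

Working notes on the series. In a functional assay on MIA PaCa-2 cells (Homo sapiens) for inhibition, read by MTT assay, with a stated time of 3 days (on this read-out higher numbers stand for weaker inhibition and lower numbers for stronger inhibition), compound 1 `CCN(CC)S(=O)(=O)c1ccc(S(=O)(=O)N2CCC[C@@H](C(=O)N(C)C(C)C)C2)cc1` gives 1400 nM, compound 2 `CCOC(=O)C1CN(S(=O)(=O)c2ccc(S(=O)(=O)N(CC)CC)cc2)C1` gives 800 nM, and compound 3 `CC(C)c1noc(N2CCN(C(=O)[C@@H]3CCCN(S(=O)(=O)c4ccc(S(=O)(=O)NC5CC5)cc4)C3)CC2)n1` gives 300 nM. Compound 3 therefore holds the lowest number of the three, with its gaps to compound 2 and to compound 1 both beyond the scatter.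

Compound 4 `CCNS(=O)(=O)c1ccc(S(=O)(=O)N2CCC[C@@H](C(=O)N3CCN(c4nc(C(C)C)no4)CC3)C2)cc1` has not been measured. Relative to compound 3 the change is ethyl in place of cyclopropyl on a sulfonamide nitrogen, in words ethyl in place of cyclopropyl on a sulfonamide nitrogen. Among the measured compounds shown here, no measured pair in this set isolates such a change, so there is no direct reference for its size. Given the small size of the exchange, the step of a 1.2-fold higher number from compound 3 to compound 4 (0.07 log units; within the scatter) is expected to stay within the scatter, with no clear direction. Compound 4 is accordingly estimated at 350 nM, with a likely range from 150 nM to 800 nM.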

Compound 4, half-maximal inhibitory concentration: 200 nM
The estimate for compound 4 lay 1.8-fold (0.24 log units) above the measured number, and the stated range covers the measured number.
By their numbers in this assay, from the lowest: compounds 4 and 3 (each within the scatter of the next); then compounds 2 and 1 (each within the scatter of the next).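

In this assay, the step of a 1.5-fold lower number from compound 3 to compound 4 (0.18 log units; within the scatter) lies within the scatter, so ethyl and cyclopropyl on this sulfonamide nitrogen cannot be told apart on this read-out. Among the compounds shown here, this is the first pair to differ in one place, and it shows that the three-membered carbon ring is not needed there to keep a number at this level. Nothing available bears on why the two groups read alike.

From the compounds shown here alone, what a butyl chain, a phenyl ring or a plain hydrogen on that nitrogen would give remains open. Going by these compounds, whether the same exchange reads alike on another core also stays open.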